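A few compounds are considered here, and "the series" means these few. Any claim that something is new, unique, unknown or untested is made for them only; others in the source may bear on it.

Working notes on the series, all read in a functional assay on DU-145 cells (Homo sapiens) for inhibition, read by trypan blue exclusion, with a stated time of 96 h; on this read-out higher numbers stand for weaker inhibition of growth and lower numbers for stronger inhibition of growth. Compound 1 `O=C(/C(=C\c1c[nH]c2ccccc12)SCc1ccc(F)cc1)c1ccc(Cl)cc1` gives 1000 nM, and compound 2 `Cc1ccc(CS/C(=C/c2sccc2C)C(=O)c2ccc(Cl)cc2)cc1` gives 10000 nM. Compound 2 therefore holds the higher of the two numbers, with a gap beyond the scatter, but the two compounds differ in more than one place. Compound 3 `Cc1ccsc1/C=C(/SCc1ccc(F)cc1)C(=O)c1ccc(Cl)cc1` departs from compound 2 in a single place: fluoro in place of methyl on an aromatic carbon, turning 4-methylbenzyl into 4-fluorobenzyl. For the measured compounds named here, no measured pair isolates this change. The 4-fluorobenzyl group also occurs in compound 1, at 1000 nM, though that compound differs elsewhere too. Only a modest shift toward a lower number is expected, close to the scatter. The expected change is a 2.0-fold lower number from compound 2 to compound 3 (0.30 log units; within the scatter). For compound 3 the estimated value is 5000 nM, with an expected range from 1500 nM to 15000 nM.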

Compound 3, concentration for 50% growth inhibition: 50000 nM
Compound 3: the middle estimate sits 10-fold (1.00 log units) below what was measured; measured number outside the range, above it.
By their numbers in this assay, from the lowest: compound 1; then compound 2; then compound 3.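

With the 3-methylthiophen-2-yl group in place, fluoro in place of methyl on the aromatic carbon para to a large group, turning 4-methylbenzyl into 4-fluorobenzyl, gives a 5.0-fold higher number from compound 2 to compound 3 (0.70 log units; beyond the scatter) in this assay and so weakens inhibition of growth; this position responds to a change of one heavy atom. With 4-fluorobenzyl held fixed, 3-methylthiophen-2-yl in place of 1H-indol-3-yl gives a 50-fold higher number from compound 1 to compound 3 (1.70 log units; beyond the scatter), the larger of the two steps, so the 1H-indol-3-yl group is linked to stronger inhibition of growth in this pair. No measurement at hand accounts for either step.

On these data alone, whether the methyl and fluoro groups rank the same way with 1H-indol-3-yl in place remains open. So does the outcome for an unsubstituted benzyl, 4-chlorobenzyl or 4-methoxybenzyl group at this position.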